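The compounds below may be only part of what the source reports. "The series", "measured", "known", "first", "only" and "open" are said of these compounds alone.

Compound 2 `Cc1cccc2c1N(Cc1ccccc1)C(=O)C21C(C#N)=C(N)Oc2cc3oc(-c4ccccc4)cc(=O)c3c(O)c21` sits at the edge of what a functional assay on A549 cells (Homo sapiens) for antiproliferative activity, read by MTT assay, with a stated time of 48 h (on this read-out lower numbers stand for stronger inhibition and higher numbers for weaker inhibition), can report: in that assay compound 2 gives > 50000 nM, which is a limit rather than a number. Compound 3 `N#CC1=C(N)Oc2cc3oc(-c4ccccc4)cc(=O)c3c(O)c2C12C(=O)N(Cc1ccccc1)c1c(Cl)cccc12` likewise gives a limit, > 50000 nM. Going by the values given here, the one step that joins these two, a step that the two limits leave unreadable from compound 2 to compound 3, cannot be sized because of the limit of > 50000 nM in this assay, at which 2 of the 3 values shown sit. Compound 1 `CN1C(=O)C2(C(C#N)=C(N)Oc3cc4oc(-c5ccccc5)cc(=O)c4c(O)c32)c2cc(Br)ccc21` differs from compound 2 in several places; in this assay compound 1 gives 3150 nM. Among the compounds with values here, the change from compound 2 to compound 4 `CCN1C(=O)C2(C(C#N)=C(N)Oc3cc4oc(-c5ccccc5)cc(=O)c4c(O)c32)c2cccc(C)c21` is methyl in place of phenyl on a saturated chain carbon bound to an amide-type nitrogen in a ring, and no measured step matches it. The expected step is an at least 2.5-fold lower number from compound 2 to compound 4 (0.39 log units; beyond the scatter), with low confidence. Compound 4 is estimated at 20000 nM, within a range from 5000 nM to 80000 nM.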

Compound 4, half-maximal inhibitory concentration: > 50000 nM
Compound 4: a limit, no number; the forecaster's own chance of this, stated with the estimate: 40%; middle value at least 2.5-fold (0.39 log units) from the limit.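

No step can be read from compound 2 to compound 4, because both give only a limit: the limit of > 50000 nM in this assay, at which 3 of the 4 values shown sit.

The compounds shown leave open whether ethyl in place of benzyl changes the result at all in this assay.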